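The compounds below may be only part of what the source reports. "The series", "measured", "known", "first", "only" and "open" are said of these compounds alone.

Measured compounds in a functional assay on K562 cells (Homo sapiens) for inhibition, read by sulforhodamine B assay, with a stated time of 48 h; a lower number here means a stronger inhibitor of growth, a higher number a weaker inhibitor of growth:
compound 1, `Nc1cc(N)c2nc(-c3ccccc3)c(Oc3ccc(Cl)c(Cl)c3)nc2c1` — compound 1 gives 3550 nM
compound 2, `Nc1cc(N)c2nc(-c3ccccc3)c(NCc3ccc(Cl)c(Cl)c3)nc2c1` — compound 2 gives 3090 nM
compound 3, `COc1ccc(CNc2nc3cc(N)cc(N)c3nc2-c2ccccc2)cc1OC` — compound 3 gives 6030 nM

In this assay compound 3 lies within the scatter of compound 1 and of compound 2; the three numbers cannot be told apart. Compound 4 is `COc1cc(CNc2nc3cc(N)cc(N)c3nc2-c2ccccc2)cc(OC)c1OC`. It differs from compound 3 by methoxy in place of hydrogen on an aromatic carbon.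

Going by the values given here, the one measured step that touches the same part of the molecule is a 2.0-fold higher number from compound 2 to compound 3 (0.29 log units; within the scatter), which exchanged 3,4-dichlorophenyl for 3,4-dimethoxyphenyl on the chain carbon without moving the number beyond the scatter. Among the compounds with values here, no measured pair shows what an added methoxy on this ring does, so the expectation rests on that single step and on the small size of the change. A step beyond the scatter is not expected in this assay, in either direction. The estimated step is a 1.0-fold lower number from compound 3 to compound 4 (0.00 log units; within the scatter). The estimate for compound 4 in this assay is 6000 nM, with a range from 3000 nM to 12000 nM.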

Compound 4, concentration for 50% growth inhibition: 1780 nM
Beside the measured number, compound 4's estimate is 3.4-fold (0.53 log units) above it; measured number outside the range, below it.
By their numbers in this assay, from the lowest: compounds 4, 2, 1 and 3 (each within the scatter of the next, the first and the last beyond it).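

In this assay, methoxy in place of hydrogen on this aromatic carbon, ortho to a methoxy group, gives a 3.4-fold lower number from compound 3 to compound 4 (0.53 log units; beyond the scatter), the only step among the compounds shown that lies beyond the scatter. Going by these compounds alone, the exchange of 3,4-dichlorophenyl for 3,4-dimethoxyphenyl gave a 2.0-fold higher number from compound 2 to compound 3 (0.29 log units; within the scatter) and stayed within the scatter, so this is the first sign that substitution on this ring can shift the number, although the shift is modest. No available evidence bears on the reason for this step.

As far as these compounds go, whether the step depends on the methoxy groups already on the ring remains open. Also open, from the compounds shown here alone, is whether an ethoxy, a hydroxy or a fluorine on the same carbon would shift the number in the same direction.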